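Moving the Chlorine on the Benzylamide Ring

The source may hold more compounds than are shown below. What is called first, only, known or untested is meant among the compounds shown, and "the series" means these compounds.

Measured so far in this assay:
compound 1, `Cc1cccc(CNC(=O)c2nn(-c3ccc(F)cc3)c(OC[C@@H](O)C[C@@H](O)CC(=O)O)c2C(C)C)c1`: 4.9 nM
compound 2, `CC(C)c1c(C(=O)NCc2ccc(Cl)cc2)nn(-c2ccc(F)cc2)c1OC[C@@H](O)C[C@@H](O)CC(=O)O`: 6.7 nM

In an assay on microsomes from liver for inhibition of 3-hydroxy-3-methylglutaryl-coenzyme A reductase (Rattus norvegicus) (a higher number here means a weaker inhibitor, a lower number a stronger inhibitor), compound 2 gives 6.7 nM, the higher of the two numbers shown, yet the only measured step, a 1.4-fold higher number from compound 1 to compound 2 (0.14 log units; within the scatter), lies within the scatter, so the two compounds are not separated.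

Compound 3, `CC(C)c1c(C(=O)NCc2ccccc2Cl)nn(-c2ccc(F)cc2)c1OC[C@@H](O)C[C@@H](O)CC(=O)O`, differs from compound 2 in one respect: 2-chlorophenyl in place of 4-chlorophenyl on a saturated chain carbon bound to an amide-type nitrogen. For the measured compounds named here, no measured step tests this particular change. Going by the values given here, the one step available, a 1.4-fold higher number from compound 1 to compound 2 (0.14 log units; within the scatter), exchanged one substituted phenyl ring for another on the same saturated chain carbon and left the number within the scatter, which suggests the benzylamide ring tolerates such swaps. A step of little size is therefore expected, a 1.3-fold higher number from compound 2 to compound 3 (0.13 log units; within the scatter), with wide uncertainty because only compound 2 at 6.7 nM and compound 1 anchor it. Compound 3 is expected to give 9 nM, in a range from 3 nM to 30 nM.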

Compound 3, half-maximal inhibitory concentration: 9.5 nM
The estimate for compound 3 lay 1.1-fold (0.02 log units) below the measured number; measured number inside the range.
By their numbers in this assay, from the lowest: compounds 1, 2 and 3 (each within the scatter of the next).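

In this assay, for the compounds shown here, moving the chlorine from 4-chlorophenyl to 2-chlorophenyl on a saturated chain carbon bound to an amide-type nitrogen gives a 1.4-fold higher number from compound 2 to compound 3 (0.15 log units; within the scatter) and is the first test here of where the chlorine sits, with the same atoms joined differently. The comparison with the 3-methylphenyl ring gives a 1.9-fold higher number from compound 1 to compound 3 (0.29 log units; within the scatter) and so leaves all three rings unseparated, whichever substituent or placement is read. Nothing measured here bears on why these rings are not separated.

Still open, going by these compounds, is whether 3-chlorophenyl, which would complete the chlorine series, also stays with these three compounds. The compounds shown carry only chlorine or methyl on this ring, so an amine or a carboxylic acid there remains untested, as does a longer chain in place of the saturated chain carbon.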